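Anilide to Morpholine Amide on a Shared Nitrobenzofurazan Core

The source may hold more compounds than are shown below. What is called first, only, known or untested is meant among the compounds shown, and "the series" means these compounds.

Measured compounds in an assay on isolated protein for inhibition of glutathione S-transferase P (Homo sapiens), with a stated time of 10 min; a higher number here means a weaker inhibitor, a lower number a stronger inhibitor:
compound 1 `COc1ccccc1NC(=O)CCC(=O)OCCCCCCSc1ccc([N+](=O)[O-])c2nonc12` gives 4050 nM
compound 2 `O=C(CCC(=O)OCCCCCCSc1ccc([N+](=O)[O-])c2nonc12)Nc1ccc(Br)cc1` gives 5090 nM
compound 3 `O=C(CCC(=O)OCCCCCCSc1ccc([N+](=O)[O-])c2nonc12)Nc1ccc(F)c(Cl)c1` gives 9850 nM

Compound 3 carries the highest number of the three in this assay, but only part of that stands out: the step of a 2.4-fold higher number from compound 1 to compound 3 (0.39 log units; beyond the scatter) lies beyond the scatter, whereas the step of a 1.9-fold higher number from compound 2 to compound 3 (0.29 log units; within the scatter) does not, and the step of a 1.3-fold higher number from compound 1 to compound 2 (0.10 log units; within the scatter) is likewise within it. The three measured compounds therefore sit close together, with compound 3 at the weak end.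

Compound 4 `O=C(CCC(=O)N1CCOCC1)OCCCCCCSc1ccc([N+](=O)[O-])c2nonc12` differs from compound 3 in one place: morpholin-4-yl in place of (3-chloro-4-fluorophenyl)amino on a carbonyl carbon. Within the data shown here, none of the measured steps bears directly on this change; each of them exchanges one aromatic group for another on the amide-type nitrogen, and all of them stay small. Among the measured compounds shown here, no step here shows what follows when the aromatic ring is removed altogether. On that basis the step is expected to be modest, with more room on the weaker side, giving an estimated step of a 1.2-fold higher number from compound 3 to compound 4 (0.09 log units; within the scatter). Compound 4 is estimated at 12000 nM, within a range from 3500 nM to 40000 nM.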

Compound 4, half-maximal inhibitory concentration: 330 nM
The estimate for compound 4 lay 36-fold (1.56 log units) above the measured number; measured number below the stated range.
By their numbers in this assay, from the lowest: compound 4; then compounds 1, 2 and 3 (each within the scatter of the next, the first and the last beyond it).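

Exchanging one aromatic group for another on the amide-type nitrogen had left the numbers in this assay close together, but replacing the arylamino group on this carbonyl carbon with morpholin-4-yl gives a 30-fold lower number from compound 3 to compound 4 (1.47 log units; beyond the scatter). The same change gives a 15-fold lower number from compound 2 to compound 4 (1.19 log units; beyond the scatter) and a 12-fold lower number from compound 1 to compound 4 (1.09 log units; beyond the scatter), so among these compounds, leaving the arylamino type for morpholin-4-yl counts for far more than which aromatic ring is carried. The change removes the aromatic ring and the hydrogen-bond donor together, and no measurement shown accounts for the gain.

As far as these compounds go, whether the gain is specific to morpholin-4-yl remains open, since a piperidin-1-yl or dimethylamino group on the same carbonyl carbon would test the role of the ring oxygen. Also open, from the compounds shown here alone, is whether it would persist with a longer chain in compound 4.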